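The compounds below may be only part of what the source reports. "The series", "measured", "known", "first", "only" and "open" are said of these compounds alone.

Of the compounds shown here, three sharing one core have been tested in a functional assay on CRL2813 cells (Homo sapiens) for cytotoxicity, read by sulforhodamine B assay, with a stated time of 5 days; on this read-out lower numbers stand for stronger inhibition and higher numbers for weaker inhibition. Compound 1, `O=C(Nc1cccc(F)c1)N[C@H]1CC[C@H](Oc2ccc(F)cc2)CC1`, carries 3-fluorophenyl on an amide-type nitrogen and gives 8300 nM. Compound 2, `O=C(Nc1ccc(Br)cc1)N[C@H]1CC[C@H](Oc2ccc(F)cc2)CC1`, carries 4-bromophenyl there and gives > 20000 nM, which is a limit of the assay and not a number. Compound 3, `O=C(Nc1ccccc1[N+](=O)[O-])N[C@H]1CC[C@H](Oc2ccc(F)cc2)CC1`, carries 2-nitrophenyl and gives 3500 nM, the lowest number of the three.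

Compound 4, `O=C(Nc1ccc([N+](=O)[O-])cc1)N[C@H]1CC[C@H](Oc2ccc(F)cc2)CC1`, is the next to be measured. In it, 4-nitrophenyl takes the place of 2-nitrophenyl on an amide-type nitrogen (4-nitrophenyl in place of 2-nitrophenyl on an amide-type nitrogen).

For the measured compounds named here, three measured steps bear on this change. The move to 2-nitrophenyl gave a 2.4-fold lower number from compound 1 to compound 3 (0.38 log units; beyond the scatter) and also an at least 5.7-fold lower number from compound 2 to compound 3 (0.75 log units; beyond the scatter), while the move to 4-bromophenyl gave an at least 2.4-fold higher number from compound 1 to compound 2 (0.38 log units; beyond the scatter). Going by the values given here, compound 2 is the only measured compound with a group at the 4 position, so a modest rise is expected, though this rests on very few compounds. The expected change is a 2.6-fold higher number from compound 3 to compound 4 (0.41 log units; beyond the scatter). For compound 4 the estimated value is 9000 nM, with an expected range from 3000 nM to 20000 nM.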

Compound 4, half-maximal inhibitory concentration: 2300 nM
Estimate against measurement, compound 4: 3.9-fold (0.59 log units) above; the whole stated range lies above it.
By their numbers in this assay, from the lowest: compounds 4 and 3 (each within the scatter of the next); then compound 1. At a limit, above all of these: compound 2.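

In this assay, moving the nitro group from 2-nitrophenyl to 4-nitrophenyl gives a 1.5-fold lower number from compound 3 to compound 4 (0.18 log units; within the scatter), so these two placements cannot be told apart here. Nitro in place of bromo gives an at least 8.6-fold lower number from compound 2 to compound 4 (0.93 log units; beyond the scatter), so among the compounds shown, a group in the place it holds in 4-bromophenyl does not by itself bring a high reading, and what compound 2 gives is a limit, not a number: the limit of > 20000 nM in this assay, at which 1 of the 4 values shown sits. 4-Nitrophenyl in place of 3-fluorophenyl gives a 3.6-fold lower number from compound 1 to compound 4 (0.56 log units; beyond the scatter), so both nitro compounds now read below compound 1.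

Going by these compounds, it remains open whether an amine or a carboxylic acid in place of the nitro group would keep these readings, and how 3-nitrophenyl would compare. On these data alone, the shared core is constant throughout, so whether the pattern holds on other cores also stays open.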